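Mirrored Ring Carbon and Tolerance by Human Fibroblasts

The source may report more compounds than this note shows. Statements on the series, on what has been measured and on what is new or still open speak of the compounds shown alone.

Compound 1, `Nc1ncnc2c1ncn2/C=C1/C[C@@H]1[C@@H](O)CO`: in an ADME assay on HFF cells (Homo sapiens) for cytotoxicity, read by neutral red uptake (a higher number here means that more compound is tolerated, a lower number that less compound is tolerated), compound 1 gives > 300000 nM, a limit of the assay rather than a number.
Compound 2, `Nc1nc2c(ncn2/C=C2\C[C@H]2[C@H](O)CO)c(=O)[nH]1`: in this assay compound 2 gives > 300000 nM, again a limit of the assay.

Both measured compounds were tolerated up to the highest concentration tested, so no numbers stand behind them. Compound 1 therefore sits at the limit of > 300000 nM in this assay, at which 2 of the 2 values shown sit, and nothing separates it from compound 2 on what has been seen.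

The untested compound 3, `Nc1ncnc2c1ncn2/C=C1/C[C@H]1[C@@H](O)CO`, differs from compound 1 as follows: the two compounds have the same atoms and bonds and differ only in configuration as drawn: 1 of 3 stereo elements differ; a stereocentre at a saturated ring carbon is drawn S in compound 1 and R in compound 3. For the measured compounds named here, no step between two measured compounds shows what such a change does in this assay. With the same atoms and bonds, no shift beyond the usual scatter is expected, and the likeliest outcome is that compound 3 again reaches the limit.

Compound 3 is thus expected to give about 300000 nM, within 150000 nM to 600000 nM, a step of a number no higher from compound 1 to compound 3 (the limit leaves the size open).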

Compound 3, half-maximal cytotoxic concentration: 194000 nM
Estimate against measurement, compound 3: 1.5-fold (0.19 log units) above, and the stated range covers the measured number.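

Changing the configuration at a single saturated ring carbon, from S to R, gives an at least 1.5-fold lower number from compound 1 to compound 3 (0.18 log units; that floor lies within the scatter) in this assay. The size of this step is only a floor, since the value of compound 1 is a limit, so the true difference could be larger or could stay within the usual scatter. Any difference belongs to that one stereocentre, because nothing else separates the two compounds: the fact that compounds 1 and 3 differ only in the configuration as drawn

The compounds shown leave open whether the same change at the ring carbon would have a similar outcome on the core of compound 2, and what changes at the other stereo elements would do. They also leave open how tolerance would respond if an amine or a carboxylic acid took the place of a hydroxyl group.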